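A few compounds are considered here, and "the series" means these few. Any claim that something is new, unique, unknown or untested is made for them only; others in the source may bear on it.

Among the compounds with values here, in a functional assay on NCI-H460 cells (Homo sapiens) for cytotoxicity, read by MTT assay, with a stated time of 72 h (on this read-out higher numbers stand for weaker inhibition and lower numbers for stronger inhibition), compound 1 (`CCN(CC)Cc1ccc2nc(NC(=O)N/N=C/c3cn(Cc4ccc(Cl)cc4)c4ccccc34)sc2c1`) gives 370 nM and holds the lower of the two numbers so far, with compound 2 (`CCN(CC)Cc1ccc2nc(NC(=O)N/N=C/c3cn(Cc4ccccc4Cl)c4ccccc34)sc2c1`) at 980 nM as its only neighbour. Within the data shown here, the one measured step of a 2.6-fold higher number from compound 1 to compound 2 (0.42 log units; beyond the scatter) is modest and comes from 2-chlorophenyl in place of 4-chlorophenyl, a change in a different place from the one at issue here. Compound 3 (`CC1CCN(Cc2ccc3nc(NC(=O)N/N=C/c4cn(Cc5ccc(Cl)cc5)c5ccccc45)sc3c2)CC1`) keeps the 4-chlorophenyl of compound 1 and carries 4-methylpiperidin-1-yl in place of diethylamino on a saturated chain carbon bound to an aromatic carbon. Among the measured compounds shown here, no measured pair tests this exchange, so neither direction has support, and the chlorophenyl step serves only as a rough gauge of size. In this assay no shift beyond the scatter is therefore expected. The estimate amounts to a 1.1-fold lower number from compound 1 to compound 3 (0.05 log units; within the scatter) as the expected step. For compound 3 the estimated value is 330 nM with an expected range from 110 nM to 1000 nM on present data.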

Compound 3, half-maximal inhibitory concentration: 400 nM
Beside the measured number, compound 3's estimate is 1.2-fold (0.08 log units) below it; measured number inside the range.
By their numbers in this assay, from the lowest: compounds 1 and 3 (each within the scatter of the next); then compound 2.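

In this assay, the exchange at this position gives a 1.1-fold higher number from compound 1 to compound 3 (0.03 log units; within the scatter). Within the data shown here, with the 4-chlorophenyl held constant, this is the first reading at the saturated chain carbon bound to an aromatic carbon, and here the open-chain diethylamino and the larger 4-methylpiperidin-1-yl, with its six-membered non-aromatic ring, are not told apart by this read-out. No measured property bears on this result.

The compounds shown leave open whether the exchange reads the same way when 2-chlorophenyl replaces 4-chlorophenyl. As far as these compounds go, it also remains open whether morpholin-4-yl, which brings a ring oxygen, or a carboxylic acid at this place would stay within the scatter of compound 1.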